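The source may hold more compounds than are shown below. What is called first, only, known or untested is meant among the compounds shown, and "the series" means these compounds.

Compound 1 `NC(=O)CCNC(=O)c1cccc(S)c1`: > 100 uM
Compound 2 `CCCC(=O)OCSc1ccc(OC)cc1C(=O)NCCC(N)=O`: > 100 uM
Compound 3 `CCCC(=O)OCSc1ccccc1C(=O)NCC(N)=O`: > 100 uM

All three compounds were tested in an ADME assay on CEM-SS cells (Homo sapiens) for cytotoxicity, read by XTT assay, with a stated time of 6 days (on this read-out higher numbers stand for lower toxicity in this test and lower numbers for higher toxicity in this test), and each entry is a limit, not a number. Compound 3 therefore has no exact position and stands with the other two at the limit of > 100 uM in this assay, at which 3 of the 3 values shown sit.

Compound 4 `CCCC(=O)OCSc1ccccc1C(=O)NCCCCCC(N)=O` carries 4-carbamoylbutyl in place of carbamoyl on a saturated chain carbon bound to an amide-type nitrogen. Going by the values given here, no measured pair shows the size of such a change. The expectation rests on the limit of compound 3 at > 100 uM. No change beyond the scatter is expected, in either direction, so the expected step is a number no higher from compound 3 to compound 4 (the limit leaves the size open). For compound 4 the estimated value is 100 uM, with an expected range of 50 uM to 200 uM.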

Compound 4, half-maximal toxic concentration: 16.3 uM
Estimate against measurement, compound 4: 6.1-fold (0.79 log units) above, outside the stated range (below it).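

In this assay, carbamoyl replaced by 4-carbamoylbutyl on a saturated chain carbon bound to an amide-type nitrogen gives an at least 6.1-fold lower number from compound 3 to compound 4 (0.78 log units; beyond the scatter). This shows that the position is not silent in this test and that the change brings higher toxicity. Compound 4 alone has an exact value, while the others remain at a limit: the limit of > 100 uM in this assay, at which 3 of the 4 values shown sit.

Going by these compounds, it remains open whether an amine or a carboxylic acid in place of the terminal carbamoyl would keep this lower number. On these data alone, it also remains open whether a longer chain would lower it further.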